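The source may report more compounds than this note shows. Statements on the series, on what has been measured and on what is new or still open speak of the compounds shown alone.

Measured so far:
In a functional assay on A2780/DX3 cells (Homo sapiens) for antiproliferative activity, read by MTT assay, with a stated time of 3 days (on this read-out higher numbers stand for weaker inhibition and lower numbers for stronger inhibition), compound 1 `COc1ccc(C2(O)SC=C(C)n3c2noc3=O)cc1` gives only a limit, > 100000 nM.
In this assay compound 2 `CC1=CSC(O)(c2ccccc2)c2noc(=O)n21` also gives only a limit, > 100000 nM.

Compound 2 thus stands at the limit of > 100000 nM in this assay, at which 2 of the 2 values shown sit, with no number of its own. The step that the two limits leave unreadable from compound 1 to compound 2 cannot be sized. Compound 3 `CC1=CSC(O)(c2ccc(C)cc2)c2noc(=O)n21` differs from compound 2 by methyl in place of hydrogen on an aromatic carbon. For the measured compounds named here, none of the measured steps bears on this change, so no direction beyond the scatter can be drawn from them. Compound 3 is therefore expected to give 100000 nM (between 30000 nM and 300000 nM), most likely again a limit. The expected step is a number no higher from compound 2 to compound 3 (the limit leaves the size open).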

Compound 3, half-maximal inhibitory concentration: > 100000 nM
Compound 3 was reported as a limit; the forecaster's own chance of this, stated with the estimate: 80%; the middle value lies on the limit itself.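

For the compounds shown here, no step among compound 1, compound 2 and compound 3 can be read, since each gives only a limit: the limit of > 100000 nM in this assay, at which 3 of the 3 values shown sit. As far as these compounds go, whether hydrogen, methyl or methoxy on that aromatic carbon makes any difference to the inhibition remains open.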